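This account rests on a few compounds, and the source may have more. Where it says the series, first, only, none or still open, it means among the compounds named here.

Within the data shown here, compound 1 `O=C(Nc1cccc(Cl)c1)Nc1nnc(Sc2ncnc3scc(-c4ccncc4)c23)s1` gives 21000 nM in a functional assay on HUVEC cells (Homo sapiens) for antiproliferative activity, read by MTT assay, with a stated time of 48 h (on this read-out lower numbers stand for stronger inhibition and higher numbers for weaker inhibition), the second highest of the three numbers measured so far; compound 3 `O=C(Nc1ccc(Cl)cc1)Nc1nnc(Sc2ncnc3scc(-c4ccncc4)c23)s1` gives 11600 nM and compound 2 `O=C(Nc1ccc(F)cc1)Nc1nnc(Sc2ncnc3scc(-c4ccncc4)c23)s1` gives 28300 nM. Both neighbours sit within the scatter of compound 1: a 1.3-fold higher number from compound 1 to compound 2 (0.13 log units; within the scatter) and a 1.8-fold lower number from compound 1 to compound 3 (0.26 log units; within the scatter). Compound 4 `O=C(Nc1cccc(F)c1)Nc1nnc(Sc2ncnc3scc(-c4ccncc4)c23)s1` differs from compound 1 by fluoro in place of chloro on an aromatic carbon. Among the measured compounds shown here, the one step that bears directly on this exchange runs the other way, on the 4-chlorophenyl and 4-fluorophenyl pair: a 2.4-fold lower number from compound 2 to compound 3 (0.39 log units; beyond the scatter). Read in reverse it points to a modestly higher number for compound 4 in this assay, with the weaker step a 1.3-fold higher number from compound 1 to compound 2 (0.13 log units; within the scatter) leaning the same way. The number for compound 4 is therefore expected to be 36000 nM, between 17000 nM and 75000 nM, a step of a 1.7-fold higher number from compound 1 to compound 4 (0.23 log units; within the scatter).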

Compound 4, half-maximal inhibitory concentration: 13700 nM
For compound 4 the middle estimate is 2.6-fold (0.42 log units) above the measured one; the whole stated range lies above it.
By their numbers in this assay, from the lowest: compounds 3, 4, 1 and 2 (each within the scatter of the next, the first and the last beyond it).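

In this assay the exchange of chloro for fluoro does not carry over between the two placements on the phenyl ring: the same change on two cores in this assay, a 2.4-fold lower number (0.39 log units; beyond the scatter) from compound 2 to compound 3 and a 1.5-fold higher number (0.19 log units; within the scatter) from compound 4 to compound 1, 3.7-fold (0.57 log units) apart, beyond the scatter of two such steps.
On the 3-chlorophenyl group the exchange gives a 1.5-fold lower number from compound 1 to compound 4 (0.19 log units; within the scatter) and the comparison with the 4-chlorophenyl group gives a 1.2-fold higher number from compound 3 to compound 4 (0.07 log units; within the scatter) so neither step separates these compounds.
The placement of fluoro does register, with a 2.1-fold lower number from compound 2 to compound 4 (0.32 log units; beyond the scatter) as the 3-fluorophenyl group replaces the 4-fluorophenyl group.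
The compounds shown carry only chloro or fluoro on this phenyl ring, so it remains open how a methoxy group, an amine or a carboxylic acid would read here.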